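Piperazine in place of trimethylpyrazole: solubility outlook

This account rests on a few compounds, and the source may have more. Where it says the series, first, only, none or still open, it means among the compounds named here.

For the measured compounds named here, in a physicochemical assay for solubility, read by LC-MS, in phosphate buffer, measured as thermodynamic solubility, with a stated time of 24 h, at pH 7.4 (on this read-out higher numbers stand for higher solubility and lower numbers for lower solubility), compound 2 `Cc1nn(C)c(C)c1-c1cnc2[nH]cc(-c3cccc(C#N)c3)c2c1` gives 5700 nM, the only number in the set; no other measured compound provides a second number to compare against. Compound 1 `Cn1cc(-c2cnc3[nH]cc(-c4ccc(O)cc4)c3c2)cn1` returns only a limit in this assay, < 3000 nM, and not a number. Compound 3 `N#Cc1cccc(-c2c[nH]c3ncc(N4CCNCC4)cc23)c1` is not yet measured; it differs from compound 2 in one place, (piperazin-1-yl in place of 1,3,5-trimethyl-1H-pyrazol-4-yl on an aromatic carbon). Going by the values given here, no measured pair covers this change, so the direction rests on expectation alone: a step upward beyond the usual scatter is expected, a 7.0-fold higher number from compound 2 to compound 3 (0.85 log units; beyond the scatter). Compound 3 is estimated at 40000 nM in this assay, within a range of 8000 nM to 200000 nM.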

Compound 3, solubility: 240000 nM
Estimate against measurement, compound 3: 6.0-fold (0.78 log units) below; the measured number lies above the stated range.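

In this assay, the group on this aromatic carbon, para to a fused ring, has a large bearing on the read-out: piperazin-1-yl in place of 1,3,5-trimethyl-1H-pyrazol-4-yl gives a 42-fold higher number from compound 2 to compound 3 (1.62 log units; beyond the scatter). For the compounds shown here, this is the only step in the set between compounds that differ in one place, and it shows that a non-aromatic ring can replace the aromatic one here with a higher number. No measurement shown accounts for the size of this step.

On these data alone, whether the step depends on the piperazine ring as a whole or on its hydrogen-bearing ring nitrogen stays open, as morpholine or 4-methylpiperazine at this position would bear on that question. As far as these compounds go, whether the step carries over to the core of compound 1 also stays open.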